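The source may hold more compounds than are shown below. What is called first, only, known or untested is meant among the compounds shown, and "the series" means these compounds.

Compound 1 `O=C(O)c1cn(C2CC2)c2c(F)c(N3CCCC3)c(F)cc2c1=O` and compound 2 `O=C(O)c1cn(C2CC2)c2c(Cl)c(N3CCCC3)c(F)cc2c1=O` share one core, while compound 3 `CC1(CN)CCN(c2c(F)cc3c(=O)c(C(=O)O)cn(C4CC4)c3c2F)C1` and compound 4 `CC1(CN)CCN(c2c(F)cc3c(=O)c(C(=O)O)cn(C4CC4)c3c2Cl)C1` share another. In a functional assay on V79 cells (Cricetulus griseus) for cytotoxicity, read by colony formation (on this read-out lower numbers stand for stronger inhibition and higher numbers for weaker inhibition), compound 1 gives 120 ug/mL, compound 2 gives 150 ug/mL, and compound 3 gives 8 ug/mL. The two cores differ by 3-(aminomethyl)-3-methylpyrrolidin-1-yl in place of pyrrolidin-1-yl on an aromatic carbon, a step of a 15-fold lower number from compound 1 to compound 3 (1.18 log units; beyond the scatter). The change chloro in place of fluoro on an aromatic carbon gave a 1.3-fold higher number from compound 1 to compound 2 (0.10 log units; within the scatter). Compound 4 carries the same kind of change, (chloro in place of fluoro on an aromatic carbon); the surroundings differ only in that the carbon is ortho to a 3-(aminomethyl)-3-methylpyrrolidin-1-yl group rather than ortho to a pyrrolidin-1-yl group. For compound 4 in this assay a step of a 1.3-fold higher number from compound 3 to compound 4 (0.10 log units; within the scatter) is expected, resting on the step of a 1.3-fold higher number from compound 1 to compound 2 (0.10 log units; within the scatter) seen on the other core. Compound 4 is therefore estimated at 10 ug/mL, with a likely range from 5 ug/mL to 20 ug/mL.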

Compound 4, half-maximal inhibitory concentration: 8 ug/mL
Compound 4: the middle estimate sits 1.3-fold (0.10 log units) above what was measured, within the range that was stated.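

In this assay, chloro in place of fluoro on the aromatic carbon gave no change at the digits printed from compound 3 to compound 4 (within the scatter), and the step carried from one core to the other: the same change on two cores in this assay, a 1.3-fold higher number (0.10 log units; within the scatter) from compound 1 to compound 2 and no change at the digits printed (within the scatter) from compound 3 to compound 4, 1.3-fold (0.10 log units) apart, within the scatter of two such steps. The amine-bearing substituent also kept its large effect with chloro in place, giving a 19-fold lower number from compound 2 to compound 4 (1.27 log units; beyond the scatter), so the two changes read as independent of each other here: the same change on two cores in this assay, a 15-fold lower number (1.18 log units; beyond the scatter) from compound 1 to compound 3 and a 19-fold lower number (1.27 log units; beyond the scatter) from compound 2 to compound 4, 1.3-fold (0.10 log units) apart, within the scatter of two such steps. Among the compounds shown here, this agreement rests on only two pairs, both with a halogen step within the scatter, so it shows that the swap made no readable difference on these two cores, not that it would transfer to other cores or other assays.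

On these data alone, it remains open how a methoxy group on that aromatic carbon would read in this assay. As far as these compounds go, it is also open whether the pattern would hold with a piperazine ring in place of the 3-(aminomethyl)-3-methylpyrrolidin-1-yl group.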